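From a Furan Amide to a Nitrophenyl Amide

This account rests on a few compounds, and the source may have more. Where it says the series, first, only, none or still open, it means among the compounds named here.

Compound 2 `O=C(CCCCCC(NC(=O)c1ccco1)C(=O)NCc1ccccc1)NO` carries a furan-2-yl group on the carbonyl carbon of its amide. Within the data shown here, in a functional assay on NFF cells (Homo sapiens) for antiproliferative activity (a higher number here means a weaker inhibitor, a lower number a stronger inhibitor), compound 2 gives 4600 nM, the highest of the three numbers measured so far. Compound 3 `CC(C)CCNC(=O)C(CCCCCC(=O)NO)NC(=O)c1ccco1` gives 4400 nM in this assay. Among the measured compounds shown here, the one measured step, a 1.0-fold lower number from compound 2 to compound 3 (0.02 log units; within the scatter), shows that the series tolerates a change at the side-chain amide without moving the number. Compound 1 `CN(C)c1ccc(C(=O)NC(CCCCCC(=O)NO)C(=O)NC2CCCc3ccccc32)cc1` differs from compound 2 in two places. In this assay compound 1 gives 1810 nM, a lower number than compound 2.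

Compound 4 `O=C(CCCCCC(NC(=O)c1ccc([N+](=O)[O-])cc1)C(=O)NCc1ccccc1)NO` is the untested compound: 4-nitrophenyl in place of furan-2-yl on a carbonyl carbon. For the measured compounds named here, no measured step alters this carbonyl position, so the step from compound 2 to compound 3 does not bear on it directly. The values of compound 1 and compound 2 show that a six-membered ring of carbon only on this carbonyl can go together with a lower number, but compound 1 also differs in a second place, so the comparison is not clean. Compound 4 is therefore expected to sit close to compound 2, leaning toward a lower number, a 1.5-fold lower number from compound 2 to compound 4 (0.19 log units; within the scatter). The estimate for compound 4 in this assay is 3000 nM, with a range from 1200 nM to 7500 nM.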

Compound 4, half-maximal inhibitory concentration: 9000 nM
Compound 4: the middle estimate sits 3.0-fold (0.48 log units) below what was measured; measured number outside the range, above it.
By their numbers in this assay, from the lowest: compound 1; then compounds 3, 2 and 4 (each within the scatter of the next, the first and the last beyond it).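

Among these compounds, at this carbonyl position, compound 4 gives the first measured step in this assay, a 2.0-fold higher number from compound 2 to compound 4 (0.29 log units; within the scatter), and 4-nitrophenyl in place of furan-2-yl cannot be told apart from the scatter of repeated measurements. This shows that a six-membered aromatic ring of carbon only on this carbonyl does not by itself go with a lower number than furan-2-yl, at least when the rest of compound 2 stays unchanged. The data at hand offer no measured property that would account for this step.

Among the compounds shown here, what remains open is whether this position responds at all in this assay, since its only step so far lies within the scatter and a single change cannot show how the ring and its substituent each contribute. Plain phenyl, 4-aminophenyl or 4-(dimethylamino)phenyl on this carbonyl, with the rest of compound 2 kept in place, would separate the ring from its substituent, and the last of these would also show what the second difference in compound 1 contributes.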